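A few compounds are considered here, and "the series" means these few. Any claim that something is new, unique, unknown or untested is made for them only; others in the source may bear on it.

In a toxicity assay on HaCaT cells (Homo sapiens) for cytotoxicity, read by CCK-8 assay, with a stated time of 24 h (on this read-out lower numbers stand for higher toxicity in this test and higher numbers for lower toxicity in this test), compound 1 (`COc1ccccc1Oc1c(N)nc(-c2ccccc2)nc1Cl`) gives "not active" (no number reported), with no number reported. For the measured compounds named here, compound 2 (`COc1ccccc1Oc1c(N)nc(-c2ccc(F)cc2)nc1Cl`) gives 42600 nM, the only number so far, so there is no second number to rank it against. Compound 3 (`COc1ccccc1Oc1c(N)nc(-c2ccc(F)cc2)nc1OCCO`) keeps the shared core of compound 2 and changes one place: 2-hydroxyethoxy in place of chloro on an aromatic carbon, with 2-hydroxyethoxy in place of chloro on an aromatic carbon. Going by the values given here, no measured step covers this change, so the expectation rests only on the single number for compound 2 and on the structural change itself. A modest step towards a higher number in this assay is expected, meaning lower toxicity in this test, and it may not go far beyond the scatter. With compound 2 at 42600 nM, it remains possible that compound 3 also returns no number, as compound 1 did. The estimate for compound 3 is 70000 nM, with an expected range from 25000 nM to 200000 nM. The expected change is a 1.6-fold higher number from compound 2 to compound 3 (0.22 log units; within the scatter).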

Compound 3, half-maximal cytotoxic concentration: 15100 nM
Compound 3: middle estimate off by 4.6-fold (0.67 log units), on the high side; measured number outside the range, below it.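

In this assay the exchange of chloro for 2-hydroxyethoxy on the aromatic carbon next to the ring nitrogen gives a 2.8-fold lower number from compound 2 to compound 3 (0.45 log units; beyond the scatter) and so moves the read-out towards higher toxicity in this test, opposite to a step towards lower toxicity. For the compounds shown here, this is the first step with a number at both ends, and it shows that the read-out in this assay responds to what sits at this position and that chloro is not required there for a number to be read, as compound 3 lacks chloro and still gives one. Nothing measured here accounts for the direction or size of this step.

A single step cannot separate the contributions of the terminal hydroxyl, the ether oxygen and the length of the chain, and methoxy, 2-methoxyethoxy, 3-hydroxypropoxy or an amine such as dimethylamino at this position would begin to do so. As far as these compounds go, it also remains open whether the same exchange gives a step of similar direction and size on the core of compound 1, which carries phenyl in place of 4-fluorophenyl.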